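The source may report more compounds than this note shows. Statements on the series, on what has been measured and on what is new or still open speak of the compounds shown alone.

Measured so far:
- compound 1 `CCCCCCCCc1ccc(CCC(CO)(CO)NC(=O)CCCCC)c2ccccc12` gives 20300 nM
- compound 2 `COc1ccc(CCC(CO)(CO)NC(C)=O)c2ccccc12` gives > 80000 nM, which is a limit and not a number
- compound 3 `CCCCCCCOc1ccc(CCC(CO)(CO)NC(=O)CCCCC)c2ccccc12` gives 21900 nM

Among the measured compounds shown here, in a functional assay on HT-29 cells (Homo sapiens) for antiproliferative activity, read by sulforhodamine B assay, with a stated time of 72 h (on this read-out higher numbers stand for weaker inhibition and lower numbers for stronger inhibition), compound 3 stands at 21900 nM, level with compound 1, the only other exact number here. Compound 4 `CCCCCCCOc1ccc(CCC(CO)(CO)NC(=O)OC(C)(C)C)c2ccccc12` differs from compound 3 in one group, tert-butoxy in place of pentyl on a carbonyl carbon. For the measured compounds named here, the one measured step, heptyloxy in place of octyl on an aromatic carbon, gave a 1.1-fold higher number from compound 1 to compound 3 (0.03 log units; within the scatter), but it lies at another place and bears only weakly on this change. Going by the values given here, no measured step touches the carbonyl carbon, so no step beyond the scatter is expected in this assay, in either direction. The estimated step, a 1.0-fold higher number from compound 3 to compound 4 (0.00 log units; within the scatter), is small. Compound 4 is expected near 22000 nM, between 8000 nM and 60000 nM, on this reading.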

Compound 4, half-maximal inhibitory concentration: 21400 nM
Compound 4: middle estimate off by 1.0-fold (0.01 log units), on the high side; measured number inside the range.
By their numbers in this assay, from the lowest: compounds 1, 4 and 3 (each within the scatter of the next). At a limit, above all of these: compound 2.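

In this assay, the change from (pentylcarbonyl)amino to (tert-butoxycarbonyl)amino gives a 1.0-fold lower number from compound 3 to compound 4 (0.01 log units; within the scatter). Among the compounds shown here, this is the first measured change on this carbonyl carbon, and it shows that a straight carbon chain there can give way to a branched group holding an oxygen atom without the value moving beyond the scatter. Nothing measured here explains why the value holds. Still open, as far as these compounds go, is whether a longer chain on this carbonyl carbon would shift the value. The same question stands for a group ending in an amine or a carboxylic acid.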